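Fluoro-to-methyl exchange on the shared core

The source may hold more compounds than are shown below. What is called first, only, known or untested is meant among the compounds shown, and "the series" means these compounds.

Compound 2 `C[C@H]1O[C@@H](n2cc(F)c(=O)[nH]c2=O)C=C(F)C1=O` gives 3300 nM in a functional assay on MOLT-4 cells (Homo sapiens) for cytotoxicity; a lower number here means a stronger inhibitor, a higher number a weaker inhibitor. Among the two numbers measured so far this is the highest; the nearest is compound 1 `C[C@H]1O[C@@H](n2ccc(=O)[nH]c2=O)C=C(F)C1=O`, which in this assay gives 2500 nM, and the two stand within the scatter of each other. Among the compounds with values here, the only measured step is a 1.3-fold higher number from compound 1 to compound 2 (0.12 log units; within the scatter), a change on the same aromatic carbon that is now in question, and it did not move the number beyond the scatter.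

Compound 3 `Cc1cn([C@H]2C=C(F)C(=O)[C@@H](C)O2)c(=O)[nH]c1=O` has not yet been measured in this assay. Its difference from compound 2 is methyl in place of fluoro on an aromatic carbon. Within the data shown here, the single measured step bears on this change only in that it exchanges a small group at the same carbon; it gives no direction, and no second step exists to cross-check it. The expectation is therefore a step of no more than the scatter in this assay, in either direction.

On that basis compound 3 is estimated at 3000 nM in this assay, with a range from 1200 nM to 7500 nM, which corresponds to an expected step of a 1.1-fold lower number from compound 2 to compound 3 (0.04 log units; within the scatter).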

Compound 3, half-maximal inhibitory concentration: 2500 nM
Beside the measured number, compound 3's estimate is 1.2-fold (0.08 log units) above it; the measured number falls inside the stated range.
By their numbers in this assay, from the lowest: compounds 1, 3 and 2 (each within the scatter of the next).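

In this assay methyl in place of fluoro gives a 1.3-fold lower number from compound 2 to compound 3 (0.12 log units; within the scatter) and methyl in place of hydrogen gives no change at the digits printed from compound 1 to compound 3 (within the scatter) in the read-out. Within the data shown here, with these steps, the position is covered by three groups instead of two, and hydrogen, fluoro and methyl on this aromatic carbon all stand within the scatter of one another, whereas the earlier pair offered only a single exchange with no cross-check. The series therefore shows no sensitivity to this exchange so far, even when a carbon group replaces a halogen or a hydrogen, and no measurement available here gives a reason for that flat result.

As far as these compounds go, whether the flat result holds for anything larger or charged on this carbon remains open, for example an ethyl group, a longer chain, an amine or a carboxylic acid. Also open, from the compounds shown here alone, is whether the same insensitivity would appear in any other assay, or for changes elsewhere on the shared core, since all three numbers come from one cell line and one position.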